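The compounds below may be only part of what the source reports. "The series", "measured", "known", "first", "only" and "open" are said of these compounds alone.

Measured compounds:
compound 1 `FC(F)(F)Oc1ccc(-c2nc3cnc(Nc4ccccn4)cc3[nH]2)cc1`: 26000 nM
compound 2 `FC(F)(F)c1cccc(-c2nc3cnc(Nc4ncccn4)cc3[nH]2)c1`: 155000 nM
compound 3 `Fc1ccnc(Nc2cc3[nH]c(-c4ccc(F)c(F)c4)nc3cn2)c1`: 166000 nM

Of the compounds shown here, three have been tested in a physicochemical assay for solubility, using the shake flask method, measured as kinetic solubility, with a stated time of 20 h, at pH 2; a lower number here means a less soluble compound, a higher number a more soluble compound. In this assay compound 1 gives 26000 nM, compound 2 gives 155000 nM and compound 3 gives 166000 nM. Compound 2 holds the second highest of the three numbers. Compound 3 lies nearest to it, and the two values fall within the scatter of the measurement, so no order can be read between them. Compound 1 is furthest from compound 2, with a lower number that lies beyond the scatter.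

Compound 4 `O=C(O)c1ccnc(Nc2cc3[nH]c(-c4cccc(C(F)(F)F)c4)nc3cn2)c1` has not yet been measured. It differs from compound 2 in one place: 4-carboxypyridin-2-yl in place of pyrimidin-2-yl on a nitrogen on an aromatic ring. The rest of the structure is shared.

Among the compounds with values here, no two measured compounds differ in one place, so the series offers no direct reference for an exchange of this kind. The measured compounds vary at two positions at once and still spread over only a modest range, so no large shift is expected here; the step in this assay is expected to stay within the scatter, with no clear direction. Compound 4 is expected to give about 120000 nM in this assay, within a range from 30000 nM to 400000 nM. This means an expected step of a 1.3-fold lower number from compound 2 to compound 4 (0.11 log units; within the scatter).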

Compound 4, solubility: < 5000 nM
Compound 4 was reported as a limit (the forecaster's own chance of this, stated with the estimate: 5%); middle value at least 24-fold (1.38 log units) from the limit.
By their numbers in this assay, from the lowest: compound 1; then compounds 2 and 3 (each within the scatter of the next). At a limit, below all of these: compound 4.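

In this assay, within the data shown here, 4-carboxypyridin-2-yl in place of pyrimidin-2-yl on a nitrogen on an aromatic ring gives an at least 31-fold lower number from compound 2 to compound 4 (1.49 log units; beyond the scatter), the first step between compounds that differ in one place, and it shows that this position can move the read-out by a large margin. Compound 4 is reported only as a limit, so the step gives a minimum size and no end point: the limit of < 5000 nM in this assay, at which 1 of the 4 values shown sits. The earlier compounds shown here, which differ in more than one place, could not separate a change at this position from changes elsewhere, whereas here the rest of the structure is shared and the whole step belongs to this single exchange.

The exchange alters the ring and adds a carboxylic acid together, so the compounds shown do not tell which of the two carries the step. As far as these compounds go, a methyl ester or a primary amide in place of the carboxylic acid on the same structure would address this, and the behaviour of compound 4 at any pH other than that of this assay also stays open.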